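A few compounds are considered here, and "the series" means these few. Any claim that something is new, unique, unknown or untested is made for them only; others in the source may bear on it.

Measured compounds in this series:

- compound 1 `O=C1C[C@H](O)C[C@@H](/C=C/c2c(Cl)cc(Cl)cc2-c2cc(Cl)cc(Cl)c2)O1`: 37 nM
- compound 2 `Cc1cc(F)ccc1-c1cc(Cl)cc(Cl)c1/C=C/[C@@H]1C[C@@H](O)CC(=O)O1`: 36 nM

In an assay for inhibition of 3-hydroxy-3-methylglutaryl-coenzyme A reductase (Rattus norvegicus) (a lower number here means a stronger inhibitor, a higher number a weaker inhibitor), compound 1 gives 37 nM and compound 2 gives 36 nM. The two numbers sit practically on top of each other: the step of a 1.0-fold lower number from compound 1 to compound 2 (0.01 log units; within the scatter) is within the scatter, so compound 2 cannot be set apart from compound 1 on these data.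

Compound 3 `Cc1ccc(-c2cc(Cl)cc(Cl)c2/C=C/[C@@H]2C[C@@H](O)CC(=O)O2)cc1` is the next member. It differs from compound 2 in one place: 4-methylphenyl in place of 4-fluoro-2-methylphenyl on an aromatic carbon. Among the measured compounds shown here, the only measured step that bears on this change is the exchange of the same aryl group, a 1.0-fold lower number from compound 1 to compound 2 (0.01 log units; within the scatter), where replacing one aryl group by another of quite different substitution left the number in this assay unchanged beyond the scatter. Two examples are a thin basis, but both point to the aryl group being exchangeable without a step in this assay that exceeds the scatter, and nothing measured argues the other way.

For compound 3 the estimate in this assay is therefore 40 nM, with a range from 18 nM to 90 nM. The expected step is a 1.1-fold higher number from compound 2 to compound 3 (0.05 log units; within the scatter), i.e. none beyond the scatter.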

Compound 3, half-maximal inhibitory concentration: 190 nM
For compound 3 the middle estimate is 4.8-fold (0.68 log units) below the measured one; the measured number lies above the stated range.
By their numbers in this assay, from the lowest: compounds 2 and 1 (each within the scatter of the next); then compound 3.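

At this position, ortho to a large group and meta to two chloro groups, the aryl group in this assay is not freely exchangeable, as the agreement of compounds 1 and 2 had suggested: 4-methylphenyl in place of 4-fluoro-2-methylphenyl gives a 5.3-fold higher number from compound 2 to compound 3 (0.72 log units; beyond the scatter) and 4-methylphenyl in place of 3,5-dichlorophenyl gives a 5.1-fold higher number from compound 1 to compound 3 (0.71 log units; beyond the scatter) on the same core. Among these three compounds, the two aryl groups carrying two substituents stay within the scatter of each other, while the one carrying a single methyl stands apart, and no compound shown goes against this, though three compounds make a narrow basis. Nothing in the data at hand accounts for this rise.

From the compounds shown here alone, the step from 4-fluoro-2-methylphenyl to 4-methylphenyl changes the fluoro group and the place of the methyl group together, so it remains open which of the two carries the difference in this assay series. Unsubstituted phenyl, 4-fluorophenyl and 2-methylphenyl at this position would separate these contributions, and a group of another kind there, such as an amine or a carboxylic acid, remains an open question too.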